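A few compounds are considered here, and "the series" means these few. Any claim that something is new, unique, unknown or untested is made for them only; others in the source may bear on it.

Of the compounds shown here, three sharing one core have been measured so far in a functional assay on PC-3 cells (Homo sapiens) for inhibition, read by MTT assay, with a stated time of 48 h, tested at 10 uM (a lower number here means less inhibition of growth, a higher number more inhibition of growth at the concentration tested), at a single concentration. Compound 1 (`CCN(CC)Cc1c(O)c([C@H]2CCN(C)C[C@H]2O)c2oc(C)cc(=O)c2c1O`) gives 2% while compound 2 (`Cc1cc(=O)c2c(O)c(CN(C)CC(=O)O)c(O)c([C@H]3CCN(C)C[C@H]3O)c2o1`) gives 20% and compound 3 (`Cc1cc(=O)c2c(O)c(CN3CCC(c4ccccc4)CC3)c(O)c([C@H]3CCN(C)C[C@H]3O)c2o1`) gives 22% in this test. Compound 2 therefore sits level with compound 3 within the scatter, and clearly apart from compound 1.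

Compound 4 (`Cc1cc(=O)c2c(O)c(CN3CC(O)CC3C(=O)O)c(O)c([C@H]3CCN(C)C[C@H]3O)c2o1`) keeps the core of compound 2 but carries 2-carboxy-4-hydroxypyrrolidin-1-yl in place of (carboxymethyl)(methyl)amino on a saturated chain carbon bound to an aromatic carbon. For the measured compounds named here, the only measured step at this place is a number 18 percentage points higher from compound 1 to compound 2 (beyond the scatter) with (carboxymethyl)(methyl)amino in place of diethylamino, and it is a modest one. Going by the values given here, the group that leaves and the group that enters both hold a carboxy unit, and no measured compound shows what the added ring and hydroxy do, so no shift beyond the scatter is expected. The expected size in this assay is no change at the digits printed from compound 2 to compound 4 (within the scatter) with neither direction favoured. Compound 4 is therefore estimated at 20% with an expected range from 7% to 34% in this measurement.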

Compound 4, percent growth inhibition at one concentration: 0%
For compound 4 the middle estimate is 20 percentage points above the measured one, and the stated range ends above it.
By their numbers in this assay, from the lowest: compounds 4 and 1 (each within the scatter of the next); then compounds 2 and 3 (each within the scatter of the next).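

In this assay, a carboxy unit at this place, on a saturated chain carbon bound to an aromatic carbon, does not by itself secure the higher number: putting 2-carboxy-4-hydroxypyrrolidin-1-yl in place of (carboxymethyl)(methyl)amino gives a number 20 percentage points lower from compound 2 to compound 4 (beyond the scatter). Comparing the same group with diethylamino gives a number 2 percentage points lower from compound 1 to compound 4 (within the scatter), so a group with a carboxy unit and a group without one can read alike here, and the outcome depends on more than the presence of that unit. No measurement on hand explains the step.

The entering group brings the five-membered ring and the hydroxy together, so the compounds shown leave open which of the two goes with the step. A 2-carboxypyrrolidin-1-yl group, which has the ring and carboxy unit without the hydroxy, and a 4-hydroxypyrrolidin-1-yl group, which has the ring and hydroxy without the carboxy unit, would help separate them.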